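Replacing a Piperidine Ring with Pyrrolidine

This account rests on a few compounds, and the source may have more. Where it says the series, first, only, none or still open, it means among the compounds named here.

- Compound 1 `CCCCCCCCOP(=O)(O)OCCSC(=S)N1CCCC1` gives > 100000 nM as a limit
- Compound 2 `CCCCCCOP(=O)(O)OCCSC(=S)N1CCCC1` gives > 100000 nM as a limit
- Compound 3 `CCCCCCCCCCCCCCCCOP(=O)(O)OCCSC(=S)N1CCCCC1` gives 34300 nM as a number

All three values come from a functional assay on PC-3 cells (Homo sapiens) for inhibition, read by MTT assay, with stated times of 18 h and 4 h (a higher number here means a weaker inhibitor, a lower number a stronger inhibitor), and are half-maximal inhibitory concentrations. In this assay, within the data shown here, compound 3 stands at 34300 nM as the only true number in the set. Compound 1 and compound 2 both rest on the limit of > 100000 nM in this assay, at which 2 of the 3 values shown sit, and that value is a limit, not a number. Among the measured compounds shown here, the one measured step is a step that the two limits leave unreadable from compound 1 to compound 2 and it offers no size to carry forward.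

Compound 4 `CCCCCCCCCCCCCCCCOP(=O)(O)OCCSC(=S)N1CCCC1` differs from compound 3 in a single group. The change is pyrrolidin-1-yl in place of piperidin-1-yl on a thiocarbonyl carbon and nothing else in the structure moves. Compound 1 and compound 2 already carry pyrrolidin-1-yl, but their chains differ from that of compound 3, so neither isolates this change. For the measured compounds named here, no measured step bears directly on it, and no size or direction can be drawn from the data. The expectation therefore rests on compound 3 at 34300 nM as its anchor, with a wide margin. The expected move is a 1.0-fold higher number from compound 3 to compound 4 (0.01 log units; within the scatter) and so no change beyond the scatter is anticipated. For compound 4 the estimated value is 35000 nM with an expected range from 14000 nM to 85000 nM in this assay as the final forecast.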

Compound 4, half-maximal inhibitory concentration: 65700 nM
Estimate against measurement, compound 4: 1.9-fold (0.27 log units) below; measured number inside the range.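

Exchanging piperidin-1-yl for pyrrolidin-1-yl on a thiocarbonyl carbon, with the rest of the structure unchanged, gives in this assay a 1.9-fold higher number from compound 3 to compound 4 (0.28 log units; within the scatter), so this swap produces no difference that can be told from the scatter. Among these compounds, with pyrrolidin-1-yl now held fixed, the chain can also be read for the first time, as an at least 1.5-fold lower number from compound 2 to compound 4 (0.18 log units; that floor lies within the scatter) and as an at least 1.5-fold lower number from compound 1 to compound 4 (0.18 log units; that floor lies within the scatter). Both steps are floors and not true sizes, so they show only that a number appears in this assay with the longest chain, while the two shorter chains stay at a limit of the assay: the limit of > 100000 nM in this assay, at which 2 of the 4 values shown sit.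

From the compounds shown here alone, it remains open how a morpholin-4-yl or an open-chain dimethylamino group would read on the same thiocarbonyl carbon, given that the two rings compared here cannot be told apart. Also unresolved are whether an octadecyl chain would carry the number further in either direction, and whether piperidin-1-yl on the octyl or hexyl chains would give a number rather than a limit.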